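A few compounds are considered here, and "the series" means these few. Any claim that something is new, unique, unknown or untested is made for them only; others in the source may bear on it.

Working notes on the series. Compound 3 `CCCCCCCCc1ccc(OCC(=O)Cn2nnc(-c3ccc(C(=O)OC)cc3)n2)cc1` gives 64% in an ADME assay on S9 fraction from liver (Rattus norvegicus) for metabolic stability, read by LC-MS, using NADPH, with a stated time of 30 min; a higher number here means that more of the compound is left, a lower number that less of the compound is left. Among the three compounds measured it stands second highest: compound 1 `CCCCCCCCc1ccc(OCC(=O)Cn2nnc(-c3cccc(Cl)c3)n2)cc1` gives 69%, within the scatter of compound 3, while compound 2 `CCCCCCCCc1ccc(OCC(=O)Cn2nnc(-c3ccccc3Cl)n2)cc1` gives 28%, far below. The measured steps, a number 41 percentage points lower from compound 1 to compound 2 (beyond the scatter) and a number 36 percentage points higher from compound 2 to compound 3 (beyond the scatter), both concern the aryl group on the core, as does a number 5 percentage points lower from compound 1 to compound 3 (within the scatter). Compound 4 `CCCCCCCCc1ccc(OCC(=O)Cn2nnc(-c3ccc(C(=O)O)cc3)n2)cc1` differs from compound 3 by hydrogen in place of methyl on an oxygen next to a carbonyl group. Among the compounds with values here, none of the measured steps touches this position, so no step bears directly on it. In the absence of a relevant step, a change of no more than the scatter is expected, though the range is wide. Compound 4 is therefore estimated at 68% (range 45% to 92%), meaning an expected step of a number 4 percentage points higher from compound 3 to compound 4 (within the scatter).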

Compound 4, percent of the compound remaining: < 5%
Compound 4 gave a limit, no number; the forecaster's own chance of this, stated with the estimate: 0%; middle value at least 63 percentage points from the limit.
By their numbers in this assay, from the lowest: compound 2; then compounds 3 and 1 (each within the scatter of the next). At a limit, below all of these: compound 4.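

In this assay, the group on this oxygen matters strongly: a number at least 59 percentage points lower from compound 3 to compound 4 (beyond the scatter), so the methyl ester and the carboxylic acid cannot be treated as interchangeable. The 4-carboxyphenyl group also separates from both chlorophenyl groups, with a number at least 23 percentage points lower from compound 2 to compound 4 (beyond the scatter) and a number at least 64 percentage points lower from compound 1 to compound 4 (beyond the scatter), whereas compound 3 stays within the scatter of compound 1. The reading for compound 4 is a limit of the assay, not a number: the limit of < 5% in this assay, at which 1 of the 4 values shown sits.

From the compounds shown here alone, whether an ethyl ester or a primary amide at this place would track compound 3 or compound 4 remains open. Going by these compounds, the position of the carboxylic acid on the phenyl ring also remains open.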